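The source may hold more compounds than are shown below. What is called first, only, known or untested is meant among the compounds shown, and "the series" means these compounds.

Measured compounds:
compound 1 `COc1cc(=O)oc2cc(OCc3cccc(F)c3)ccc12`, 36.3 nM in an assay on isolated protein (strain Sprague-Dawley) for inhibition of Amine oxidase [flavin-containing] B (Rattus norvegicus), read by spectrophotometry, with a stated time of 5 min; on this read-out lower numbers stand for stronger inhibition and higher numbers for weaker inhibition
compound 2 `CCOc1cc(=O)oc2cc(OCc3cccc(F)c3)ccc12`, 263 nM in this assay
compound 3 `CC(C)Oc1cc(=O)oc2cc(OCc3cccc(Cl)c3)ccc12`, 24500 nM in this assay

Compound 3 stands highest of the three numbers; its nearest neighbour is compound 2, and compound 1 lies furthest from it, both well beyond the scatter. The step to compound 4 `O=c1cc(Oc2ccccc2)c2ccc(OCc3cccc(Cl)c3)cc2o1` is phenyl in place of isopropyl on an oxygen on an aromatic ring. Among the compounds with values here, only one measured step bears on this position on the shared core: a 7.2-fold higher number from compound 1 to compound 2 (0.86 log units; beyond the scatter). Within the data shown here, compounds 2 and 3 differ in two places at once, so their pair gives no clean step, but their values show a still higher number for the larger group. Within these three compounds, then, each enlargement of the group on that oxygen has come with a weaker result in this assay. Phenyl is larger again by the count shown, though it is of a different kind from the chain groups measured, so the direction of the step is not secured by the data. Compound 4 is therefore expected to sit near compound 3 or somewhat weaker, with a wide range: an estimated 35000 nM, between 6000 nM and 200000 nM, which would mean an expected 1.4-fold higher number from compound 3 to compound 4 (0.15 log units; within the scatter).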

Compound 4, half-maximal inhibitory concentration: 4070 nM
The estimate for compound 4 lay 8.6-fold (0.93 log units) above the measured number; the measured number lies below the stated range.
By their numbers in this assay, from the lowest: compound 1; then compound 2; then compound 4; then compound 3.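

In this assay, the change from isopropoxy to phenoxy gives a 6.0-fold lower number from compound 3 to compound 4 (0.78 log units; beyond the scatter), so a larger group on this oxygen does not always go with a higher number. The earlier step, a 7.2-fold higher number from compound 1 to compound 2 (0.86 log units; beyond the scatter), pointed the other way for methyl in place of hydrogen on the chain, and compound 4 now stands against any rule that more heavy atoms on this oxygen give a higher number: phenyl has more than isopropyl, yet its number is the lower of the two. What separates the aromatic ring from the branched chain here remains unexplained, as no supporting data bear on this result.

The compounds shown leave open whether the ring itself or some other feature of phenyl accounts for the step, and a cyclohexyl or benzyl group on the same oxygen would help separate these readings. They also leave open whether the step would carry over to the fluoro-substituted series of compound 1 and compound 2, since the phenyl and isopropyl pair has been read only with the chloro-substituted benzyl group.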